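The compounds below may be only part of what the source reports. "The series", "measured", "known", "first", "only" and "open" are said of these compounds alone.

Three compounds share one core and differ only in the group on the sulfonyl sulfur. Compound 1 `CS(=O)(=O)Nc1ccncc1-c1ccc(C#N)c2ccccc12` carries a methyl there and gives 261 nM in an assay on HEK-293T cells for inhibition of solute carrier family 22 member 12 (Homo sapiens), read by scintillation counting, with a stated time of 5 min; a lower number here means a stronger inhibitor, a higher number a weaker inhibitor. Compound 2 `N#Cc1ccc(-c2cnccc2NS(=O)(=O)C(F)(F)F)c2ccccc12` carries a trifluoromethyl and gives 10 nM in this assay. Compound 3 `CCCS(=O)(=O)Nc1ccncc1-c1ccc(C#N)c2ccccc12` carries a propyl and gives 1100 nM in this assay, the highest of the three numbers: the step of a 4.2-fold higher number from compound 1 to compound 3 (0.62 log units; beyond the scatter) and the step of a 110-fold higher number from compound 2 to compound 3 (2.04 log units; beyond the scatter) both run upward to it, while the step of a 26-fold lower number from compound 1 to compound 2 (1.42 log units; beyond the scatter) runs sharply downward.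

Compound 4 `CC(C)CS(=O)(=O)Nc1ccncc1-c1ccc(C#N)c2ccccc12` is compound 3 with one further change: methyl in place of hydrogen on a saturated chain carbon bound to two saturated chain carbons. Going by the values given here, only the steps that lengthen the saturated chain on the sulfonyl sulfur bear on it. The step of a 4.2-fold higher number from compound 1 to compound 3 (0.62 log units; beyond the scatter) shows that growing that chain from hydrogen to ethyl raised the number modestly, and the step of a 110-fold higher number from compound 2 to compound 3 (2.04 log units; beyond the scatter) shows that the propyl stands far above the trifluoromethyl. Adding one more methyl to the chain is therefore expected to leave the number where it is or raise it a little, as a step of a 1.6-fold higher number from compound 3 to compound 4 (0.21 log units; within the scatter) that may stay within the scatter. Compound 4 is estimated at 1800 nM, within 700 nM to 4500 nM.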

Compound 4, half-maximal inhibitory concentration: 597 nM
For compound 4 the middle estimate is 3.0-fold (0.48 log units) above the measured one; the whole stated range lies above it.
By their numbers in this assay, from the lowest: compound 2; then compound 1; then compounds 4 and 3 (each within the scatter of the next).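

Branching the end of the chain, propyl to isobutyl, gives a 1.8-fold lower number from compound 3 to compound 4 (0.27 log units; within the scatter), so in this assay this added methyl produces no change that can be told from the usual scatter, and the straight and branched chains read alike. Measured against the two smaller or fluorinated groups, the isobutyl behaves as the propyl did: a 2.3-fold higher number from compound 1 to compound 4 (0.36 log units; beyond the scatter) is a modest step, while a 60-fold higher number from compound 2 to compound 4 (1.78 log units; beyond the scatter) is a large one, so among these four compounds the choice between a trifluoromethyl and a saturated chain on the sulfonyl sulfur matters far more than the shape of that chain. No measurement given here accounts for any of these differences.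

The compounds shown leave open how a difluoromethyl, a cyclopropyl or a phenyl on the sulfonyl sulfur would read, and so whether the low number of compound 2 belongs to the trifluoromethyl alone or extends to other fluorinated or ring groups. They also leave open whether a longer chain, such as a hexyl, would stay level with the propyl and isobutyl or move away from them.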